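Weak cytotoxicity across a small oxadiazole thioether set

The compounds below may be only part of what the source reports. "The series", "measured", "known", "first", "only" and "open" are said of these compounds alone.

Measured so far:
compound 1 `Cn1nc(-c2ccc(C(F)(F)F)cc2)cc1-c1nnc(SCc2ccc(C(F)(F)F)cc2)o1` — 27300 nM
compound 2 `Cn1nc(-c2ccc(C(F)(F)F)cc2)cc1-c1nnc(SCCc2ccc(F)cc2)o1` — 39500 nM

Both compounds share one core and differ only in the group on the saturated chain carbon bound to the sulfur. In a functional assay on Ehrlich cells (Mus musculus) for cytotoxicity, read by MTT assay, with a stated time of 24 h (on this read-out lower numbers stand for stronger inhibition and higher numbers for weaker inhibition), compound 1 gives 27300 nM, and compound 2 gives 39500 nM. The step of a 1.4-fold higher number from compound 1 to compound 2 (0.16 log units; within the scatter) is the only one measured, and it lies within the scatter. Compound 2 has the highest of the two numbers, with compound 1 nearest.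

Compound 3 `Cn1nc(-c2ccc(C(F)(F)F)cc2)cc1-c1nnc(SCc2cccc([N+](=O)[O-])c2)o1` is not yet measured. It differs from compound 2 by 3-nitrophenyl in place of 4-fluorobenzyl on a saturated chain carbon bound to a sulfur. Among the measured compounds shown here, the one step that bears on this change, a 1.4-fold higher number from compound 1 to compound 2 (0.16 log units; within the scatter), altered the same part of the molecule and stayed within the scatter, so no shift beyond the scatter is expected in this assay. Compound 3 is therefore estimated at 33000 nM, within 12000 nM to 90000 nM, meaning an expected step of a 1.2-fold lower number from compound 2 to compound 3 (0.08 log units; within the scatter).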

Compound 3, half-maximal inhibitory concentration: > 100000 nM
Compound 3 was reported as a limit; the forecaster's own chance of this, stated with the estimate: 10%; middle value at least 3.0-fold (0.48 log units) away from the limit.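

In this assay, this position shows its first change beyond the scatter: 3-nitrophenyl in place of 4-fluorobenzyl gives an at least 2.5-fold higher number from compound 2 to compound 3 (0.40 log units; beyond the scatter), and 3-nitrophenyl in place of 4-(trifluoromethyl)phenyl gives an at least 3.6-fold higher number from compound 1 to compound 3 (0.56 log units; beyond the scatter). The position is therefore not indifferent to the group it carries, and the flat picture left by compound 1 and compound 2, which lie within the scatter of each other, does not extend to compound 3. The reading for compound 3 is a limit of the assay and not a number, so both steps give only a lower bound on their size: the limit of > 100000 nM in this assay, at which 1 of the 3 values shown sits.

Going by these compounds, how far compound 3 actually lies from the other two remains unknown. On these data alone, it also remains open whether the nitro group itself goes with this weaker result, and how an amine or a carboxylic acid in its place would read.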